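Fluoro in Place of Methyl on a Second Core

This account rests on a few compounds, and the source may have more. Where it says the series, first, only, none or still open, it means among the compounds named here.

Measured so far, in a functional assay on HT-29 cells (Homo sapiens) for cytotoxicity, read by MTT assay, with a stated time of 72 h; a higher number here means a weaker inhibitor, a lower number a stronger inhibitor:
- compound 1 `COc1cc2c(Oc3ccc(NC(=O)c4cc(-c5ccccc5C)ccn4)cc3F)ccnc2cc1OCCCN1CCCC1`: 1150 nM
- compound 2 `COc1cc2c(Oc3ccc(NC(=O)c4cc(-c5ccccc5F)ccn4)cc3F)ccnc2cc1OCCCN1CCCC1`: 230 nM
- compound 3 `COc1cc2c(Oc3ccc(NC(=O)c4nccc(-c5ccc(C)cc5)n4)cc3F)ccnc2cc1OCCCN1CCCCC1`: 620 nM

Compound 1 and compound 2 differ in one place, (fluoro in place of methyl on an aromatic carbon), and this gave a 5.0-fold lower number from compound 1 to compound 2 (0.70 log units; beyond the scatter). Compound 4 `COc1cc2c(Oc3ccc(NC(=O)c4nccc(-c5ccc(F)cc5)n4)cc3F)ccnc2cc1OCCCN1CCCCC1` carries the same kind of change against compound 3, (fluoro in place of methyl on an aromatic carbon), but the place is not the same: in compound 2 the fluoro sits ortho to a large group, in compound 4 para to a large group. The difference between the two cores is not broken down here. Because the earlier step of a 5.0-fold lower number from compound 1 to compound 2 (0.70 log units; beyond the scatter) was modest and the surroundings differ, a smaller step is expected for compound 4, a 2.5-fold lower number from compound 3 to compound 4 (0.39 log units; beyond the scatter). Compound 4 is therefore estimated at 250 nM in this assay, within 100 nM to 600 nM.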

Compound 4, half-maximal inhibitory concentration: 120 nM
Beside the measured number, compound 4's estimate is 2.1-fold (0.32 log units) above it; low and high end bracket the measured number.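

On the core of compound 3, fluoro in place of methyl gave, in this assay, a 5.2-fold lower number from compound 3 to compound 4 (0.71 log units; beyond the scatter) as 4-methylphenyl became 4-fluorophenyl. The change carried over between the two cores at much the same size, although it sits in a different place on each: the same change on two cores in this assay, a 5.0-fold lower number (0.70 log units; beyond the scatter) from compound 1 to compound 2 and a 5.2-fold lower number (0.71 log units; beyond the scatter) from compound 3 to compound 4, 1.0-fold (0.01 log units) apart, within the scatter of two such steps. This rests on just two pairs of compounds in one assay, so it shows agreement between these two cores but neither predicts the step on a further core nor explains why the number falls.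

The compounds shown leave open how chloro, methoxy or an amine would compare with fluoro at these places. They also leave open whether fluoro at the same place on both cores would give matching steps.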